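A step from 2,4-dichlorophenyl to 4-aminophenyl

A few compounds are considered here, and "the series" means these few. Any claim that something is new, unique, unknown or untested is made for them only; others in the source may bear on it.

Compound 1 `COc1cc(-c2ncnn2-c2ccc(Cl)cc2Cl)cc(OC)c1OC`: > 10000 nM (a limit)
Compound 2 `COc1cc(-n2ncnc2-c2ccc(Cl)cc2)cc(OC)c1OC`: > 10000 nM (a limit)

Both compounds were tested in a functional assay on A549 cells (Homo sapiens) for antiproliferative activity, read by MTT assay, with a stated time of 72 h; a lower number here means a stronger inhibitor, a higher number a weaker inhibitor. In this assay compound 1 gives only a limit, > 10000 nM, and no number. Compound 2 also gives only a limit, > 10000 nM. The measurements so far therefore consist entirely of the limit of > 10000 nM in this assay, at which 2 of the 2 values shown sit, and compound 1 has no numeric position in the series.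

Compound 3 `COc1cc(-c2ncnn2-c2ccc(N)cc2)cc(OC)c1OC` keeps the core of compound 1 and carries 4-aminophenyl in place of 2,4-dichlorophenyl on an aromatic nitrogen. Going by the values given here, no measured step gives the size of this change. The expectation rests on the structural change alone, and it is held loosely. A move towards stronger inhibition in this assay is expected, of moderate but uncertain size, and another limit remains possible. The expected step is an at least 5.0-fold lower number from compound 1 to compound 3 (0.69 log units; beyond the scatter). For compound 3 the estimated value is 2000 nM. The expected range for this estimate runs from 150 nM to 10000 nM.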

Compound 3, half-maximal inhibitory concentration: > 10000 nM
Compound 3: only a limit was reported; the forecaster's own chance of this, stated with the estimate: 25%; middle value at least 5.0-fold (0.69 log units) away from the limit.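

In this assay compound 3 gives > 10000 nM, a limit and not a number. Going by these compounds alone, compound 1 also gives only a limit, so no step between compound 1 and compound 3 can be read. The compounds shown leave open whether 4-aminophenyl and 2,4-dichlorophenyl differ at all in this assay, because every value shown is that same limit: the limit of > 10000 nM in this assay, at which 3 of the 3 values shown sit.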